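The compounds below may be only part of what the source reports. "The series", "measured", "known", "first", "only" and "open" are said of these compounds alone.

Compound 2 `O=C(O)CC/C=C\C[C@@H]1CN(S(=O)(=O)c2ccc(Cl)cc2)C[C@@H]1c1ccccc1O` gives the lowest number of the three measured compounds in a functional assay (Cavia porcellus) for antagonist activity at thromboxane A2 receptor (Homo sapiens) (a lower number here means tighter binding, a higher number weaker binding), at 1 nM. Compound 1 `O=C(O)CC/C=C\C[C@@H]1CN(S(=O)(=O)c2cccc3ccccc23)C[C@@H]1c1ccccc1O` gives 1.59 nM, and compound 3 `O=C(O)CC/C=C\C[C@@H]1CN(S(=O)(=O)c2ccc(Cl)cc2)C[C@H]1c1ccccc1O` gives 12.6 nM. The step of a 1.6-fold lower number from compound 1 to compound 2 (0.20 log units; within the scatter) shows that swapping the bicyclic aromatic group for a single chlorinated ring barely mattered, whereas a 13-fold higher number from compound 2 to compound 3 (1.10 log units; beyond the scatter) was large, which fits (the fact that compounds 2 and 3 differ only in the configuration as drawn). Compound 4 `O=C(O)CC/C=C\C[C@@H]1CN(S(=O)(=O)c2cccc3cnccc23)C[C@@H]1c1ccccc1O` differs from compound 2 by isoquinolin-5-yl in place of 4-chlorophenyl on a sulfonyl sulfur. Among the compounds with values here, the only measured step that bears on this change is the one between compound 1 and compound 2, which stayed within the scatter, so the return to a bicyclic aromatic group is expected to move this assay little if at all. Compound 4 is therefore estimated at 1.6 nM, between 0.5 nM and 5 nM, an expected step of a 1.6-fold higher number from compound 2 to compound 4 (0.20 log units; within the scatter).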

Compound 4, dissociation constant: 0.316 nM
Estimate against measurement, compound 4: 5.1-fold (0.70 log units) above; the measured number lies below the stated range.
By their numbers in this assay, from the lowest: compound 4; then compounds 2 and 1 (each within the scatter of the next); then compound 3.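

In this assay the group on the sulfonyl sulfur proves able to shift the number beyond the scatter: isoquinolin-5-yl gives a 3.2-fold lower number from compound 2 to compound 4 (0.50 log units; beyond the scatter) and also a 5.0-fold lower number from compound 1 to compound 4 (0.70 log units; beyond the scatter) at this same place. The second step swaps one two-ring aromatic group for another, so the second ring alone does not account for the lower number; compound 4 also carries a ring nitrogen.

From the compounds shown here alone, whether a quinolin-5-yl or pyridin-3-yl group on the same sulfur would also give a lower number remains open. Nothing in the data gives a reason for these two steps.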